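This account rests on a few compounds, and the source may have more. Where it says the series, first, only, none or still open, it means among the compounds named here.

Compound 1 `O=C1CC[C@@H](CN(Cc2ccc(F)cc2)S(=O)(=O)c2ccc(F)cc2)N1`: 3
Compound 2 `N#Cc1ccc(S(=O)(=O)N(Cc2ccc(F)cc2)C[C@@H]2CCC(=O)N2)cc1`: 2.6

In a physicochemical assay for lipophilicity (on this read-out higher numbers stand for higher lipophilicity and lower numbers for lower lipophilicity), compound 1 gives 3, the higher of the two numbers; its nearest neighbour is compound 2, at 2.6. Among the compounds with values here, the single measured step, a number 0.40 log units lower from compound 1 to compound 2 (beyond the scatter), bears directly on the change now considered. Compound 3 `N#Cc1ccccc1S(=O)(=O)N(Cc1ccc(F)cc1)C[C@@H]1CCC(=O)N1` differs from compound 1 by 2-cyanophenyl in place of 4-fluorophenyl on a sulfonyl sulfur, again placing a nitrile where a fluorine stood, now as 2-cyanophenyl. A downward step of similar modest size in this assay is therefore expected, a number 0.50 log units lower from compound 1 to compound 3 (beyond the scatter). Compound 3 is estimated at 2.5, with a range from 2.1 to 2.9.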

Compound 3, distribution coefficient: 2.5
Compound 3: middle estimate and measured number agree at the digits printed; low and high end bracket the measured number.
By their numbers in this assay, from the lowest: compounds 3 and 2 (each within the scatter of the next); then compound 1.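

In this assay, 2-cyanophenyl in place of 4-fluorophenyl on the sulfonyl sulfur gives a number 0.50 log units lower from compound 1 to compound 3 (beyond the scatter) and so shows that the earlier drop was not unique to 4-cyanophenyl. Exchanging 4-cyanophenyl for 2-cyanophenyl gives a number 0.10 log units lower from compound 2 to compound 3 (within the scatter) and so does not separate these two nitrile-bearing groups. Nothing available here explains these numbers. On these data alone, what remains open is how a phenyl group carrying an amine or a carboxylic acid on the sulfonyl sulfur would read in this assay and whether 3-cyanophenyl would match these two groups.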